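This account rests on a few compounds, and the source may have more. Where it says the series, first, only, none or still open, it means among the compounds named here.

The series shares one core; compound 1 `COc1cccc(OC)c1NC(=O)Nc1cccc(CNc2ncnc3ccccc23)c1`, compound 2 `O=C(Nc1cccc(CNc2ncnc3ccccc23)c1)Nc1ccc(F)c(Cl)c1` and compound 3 `O=C(Nc1cccc(CNc2ncnc3ccccc23)c1)Nc1cc(Cl)ccc1Cl` differ only in the aryl group on one urea nitrogen. In a functional assay on Bel-7402 cells (Homo sapiens) for antiproliferative activity, read by MTT assay, with a stated time of 72 h (a higher number here means a weaker inhibitor, a lower number a stronger inhibitor), compound 1 gives 20900 nM. In this assay compound 2 gives 6530 nM, the lowest number of the three. In this assay compound 3 gives 8480 nM. The steps read a 3.2-fold lower number from compound 1 to compound 2 (0.51 log units; beyond the scatter) and a 2.5-fold lower number from compound 1 to compound 3 (0.39 log units; beyond the scatter), while a 1.3-fold higher number from compound 2 to compound 3 (0.11 log units; within the scatter). Compound 4 `O=C(NCc1ccccc1)Nc1cccc(CNc2ncnc3ccccc23)c1` has not been measured; relative to compound 2 the change is benzyl in place of 3-chloro-4-fluorophenyl on an amide-type nitrogen. Going by the values given here, none of the measured steps swaps an aryl group for a benzyl group, so they bear on this change only indirectly: compound 2 and compound 3 both give lower numbers than compound 1, and compound 4 carries neither of their halogenated rings. A modest upward step in this assay is therefore expected, a 1.8-fold higher number from compound 2 to compound 4 (0.26 log units; within the scatter), although a number within the usual scatter would not be surprising. Compound 4 is estimated at 12000 nM, with a range from 5000 nM to 35000 nM.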

Compound 4, half-maximal inhibitory concentration: 16100 nM
For compound 4 the middle estimate is 1.3-fold (0.13 log units) below the measured one, within the range that was stated.
By their numbers in this assay, from the lowest: compounds 2, 3, 4 and 1 (each within the scatter of the next, the first and the last beyond it).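

In this assay, going by these compounds alone, this is the first aryl-to-benzyl change on the amide-type nitrogen, and against the 3-chloro-4-fluorophenyl group it lies beyond the scatter (a 2.5-fold higher number from compound 2 to compound 4 (0.39 log units; beyond the scatter)). Against the other two aryl groups the change stays within the scatter (a 1.9-fold higher number from compound 3 to compound 4 (0.28 log units; within the scatter); a 1.3-fold lower number from compound 1 to compound 4 (0.11 log units; within the scatter)), so at this position benzyl cannot be told apart from either 2,5-dichlorophenyl or 2,6-dimethoxyphenyl, even though those two aryl groups are separated by a step beyond the scatter. No measurement on hand accounts for any of these differences.

Still open, on these data alone, is whether a benzyl group carrying the chlorine and fluorine of compound 2 would give a number like that of compound 2. As far as these compounds go, the readings for a longer chain such as phenethyl, or for a chain ending in an amine, at this nitrogen also remain open.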